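The compounds below may be only part of what the source reports. "The series", "measured", "known", "first", "only" and "open" are said of these compounds alone.

Compound 2 `CC1=C(C(=O)Nc2ccc(Cl)cc2)C(c2ccc(N(C)C)cc2)C(C(=O)Nc2ccc(Cl)cc2)=C(C)N1` and compound 1 `CC1=C(C(=O)Nc2ccc(Cl)cc2)C(c2ccncc2)C(C(=O)Nc2ccc(Cl)cc2)=C(C)N1` share a core and differ in one place: pyridin-4-yl in place of 4-(dimethylamino)phenyl on a saturated ring carbon. In an ADME assay on Vero cells (Chlorocebus sabaeus) for cytotoxicity, read by sulforhodamine B assay, with a stated time of 3 days (a lower number here means that less compound is tolerated, a higher number that more compound is tolerated), compound 2 gives 155 ug/mL, and compound 1 gives 78 ug/mL; the step between them is a 2.0-fold lower number from compound 2 to compound 1 (0.30 log units; within the scatter). Compound 3 `COc1ccc(NC(=O)C2=C(C)NC(=O)NC2c2ccc(N(C)C)cc2)cc1` is built on a different core, and the difference between the two cores is not broken down here. In this assay compound 3 gives 236 ug/mL, a number within the scatter of compound 2 and beyond the scatter of compound 1. Compound 4 `COc1ccc(NC(=O)C2=C(C)NC(=O)NC2c2ccncc2)cc1` has not been measured. It differs from compound 3 in one place: pyridin-4-yl in place of 4-(dimethylamino)phenyl on a saturated ring carbon. This is the same kind of change as that from compound 2 to compound 1, but the surroundings differ: in compound 3 the place lies on a six-membered non-aromatic ring with 2 nitrogen, next to the ring nitrogen and next to the ring atom that bears a large group, whereas in compound 2 it lies on a ring with 1 nitrogen, next to two ring atoms that each bear a (4-chlorophenyl)carbamoyl group. Among the measured compounds shown here, the only precedent for this change is the step of a 2.0-fold lower number from compound 2 to compound 1 (0.30 log units; within the scatter). On that basis the expected step in this assay is a 1.8-fold lower number from compound 3 to compound 4 (0.26 log units; within the scatter), of similar size. For compound 4 the estimate in this assay is 130 ug/mL, with a range from 60 ug/mL to 300 ug/mL.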

Compound 4, half-maximal cytotoxic concentration: 10 ug/mL
Beside the measured number, compound 4's estimate is 13-fold (1.11 log units) above it; measured number outside the range, below it.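

In this assay, pyridin-4-yl in place of 4-(dimethylamino)phenyl gives a 24-fold lower number from compound 3 to compound 4 (1.37 log units; beyond the scatter), so on this core far less compound is tolerated after the change. The same change does not carry over with the same size from one core to the other: the same change on two cores in this assay, a 2.0-fold lower number (0.30 log units; within the scatter) from compound 2 to compound 1 and a 24-fold lower number (1.37 log units; beyond the scatter) from compound 3 to compound 4, 12-fold (1.07 log units) apart, beyond the scatter of two such steps. This shows that the step on the core of compound 2 cannot simply be transferred to the core of compound 3 in this series, but with a single pair on each core it does not show which part of the cores sets the gap, nor whether the gap would hold for any other group at this place.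

The compounds shown leave open whether an unsubstituted phenyl or a pyridin-3-yl at this place would show the same gap between the two cores. They also leave open whether a 4-chlorophenyl amide on the core of compound 3, in place of the methoxy-bearing one, would alter the step.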